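The source may hold more compounds than are shown below. What is called first, only, known or untested is meant among the compounds shown, and "the series" means these compounds.

Of the compounds shown here, three have been measured in an in vitro assay on BTI-TN-5B1-4 cells for inhibition of Amine oxidase [flavin-containing] A (Homo sapiens), read by Amplex Red, with a stated time of 15 min, tested at 100 uM; a lower number here means less inhibition, a higher number more inhibition at the concentration tested (going by the name of the read-out). Compound 1 `N#Cc1ccc(-c2csc(N/N=C\c3ccco3)n2)cc1` gives 40% in this assay, and compound 3 `O=[N+]([O-])c1ccc(-c2csc(N/N=C\c3ccco3)n2)cc1` gives 40%. The two differ by a single change, (nitro in place of cyano on an aromatic carbon), and the step of no change at the digits printed from compound 1 to compound 3 (within the scatter) lies within the scatter. Compound 2 `C/C(=N/Nc1nc(-c2ccc(C#N)cc2)cs1)c1cccnc1` is built on another core; the difference between the two cores is not broken down here. In this assay compound 2 gives 40%, level with compound 1 and compound 3. Compound 4 `C/C(=N/Nc1nc(-c2ccc([N+](=O)[O-])cc2)cs1)c1cccnc1` is yet to be measured in this assay. It differs from compound 2 by nitro in place of cyano on an aromatic carbon, the same change as that between compound 1 and compound 3. The step of no change at the digits printed from compound 2 to compound 4 (within the scatter) is expected to be small, because the step of no change at the digits printed from compound 1 to compound 3 (within the scatter) stayed within the scatter. Compound 4 is therefore estimated to give 40%, between 30% and 50%.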

Compound 4, a percentage reported as inhibition, at one concentration (the size of the read-out at that concentration, not a potency): "not active" (no number reported)
Nothing numeric was reported for compound 4; the estimate stays without a comparison.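

Going by these compounds alone, no step from compound 2 to compound 4 can be read, since compound 4 carries only the words "not active" and no number. The compounds shown leave open whether nitro in place of cyano matters on the core of compound 2, and no data here bear on this.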